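Shortening a Sulfur-Bound Chain in Compound 4

A few compounds are considered here, and "the series" means these few. Any claim that something is new, unique, unknown or untested is made for them only; others in the source may bear on it.

Compound 1 `O=c1c2ccccc2[se]n1-c1nc(SCc2ccc(Cl)cc2)n[nH]1` is one of three close relatives tested in a functional assay on A549 cells (Homo sapiens) for antiproliferative activity, read by CCK-8 assay, with a stated time of 48 h (on this read-out higher numbers stand for weaker inhibition and lower numbers for stronger inhibition), where compound 1 gives 42100 nM. Compound 2 `O=c1c2ccccc2[se]n1-c1nc(SCc2ccc(F)cc2)n[nH]1` gives 36400 nM, and compound 3 `CCCSc1n[nH]c(-n2[se]c3ccccc3c2=O)n1` gives 45500 nM. Compound 1 stands as the second highest of these three numbers, but all three lie within the scatter of one another, so none of them can be called stronger or weaker than the rest.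

Compound 4 `CCSc1n[nH]c(-n2[se]c3ccccc3c2=O)n1` has not yet been measured. It differs from compound 1 in one place: methyl in place of 4-chlorophenyl on a saturated chain carbon bound to a sulfur. The closest guide is the step in which ethyl replaced 4-chlorophenyl on the same saturated chain carbon bound to a sulfur, which gave a 1.1-fold higher number from compound 1 to compound 3 (0.03 log units; within the scatter). The related step of a 1.3-fold higher number from compound 2 to compound 3 (0.10 log units; within the scatter) likewise stayed within the scatter. Removing the aromatic ring from this chain therefore appears to leave the read-out where it is, and no step beyond the scatter is expected for a 1.0-fold higher number from compound 1 to compound 4 (0.02 log units; within the scatter). Compound 4 is estimated at 44000 nM, with a range from 25000 nM to 80000 nM.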

Compound 4, half-maximal inhibitory concentration: 39600 nM
Beside the measured number, compound 4's estimate is 1.1-fold (0.05 log units) above it; low and high end bracket the measured number.
By their numbers in this assay, from the lowest: compounds 2, 4, 1 and 3 (each within the scatter of the next).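

In this assay, the group on sulfur can be cut from 4-chlorobenzyl to ethyl with a 1.1-fold lower number from compound 1 to compound 4 (0.03 log units; within the scatter), and the fluoro relative behaves alike, with a 1.1-fold higher number from compound 2 to compound 4 (0.04 log units; within the scatter). Hydrogen in place of methyl on a saturated chain carbon, two bonds along the chain from a sulfur, gives a 1.1-fold lower number from compound 3 to compound 4 (0.06 log units; within the scatter), so a further shortening of the chain also stays within the scatter. Across these four compounds, no step at this position lies beyond the scatter, with or without the aromatic ring, and nothing shown offers a reason for this flat result.

As far as these compounds go, it remains open whether a chain ending in an amine or a carboxylic acid would move the number away from this narrow band. The compounds shown also cannot tell whether a much longer chain would do so, or whether this position would respond differently on another core.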